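Small steps expected from swapping the pyridine group

The source may report more compounds than this note shows. Statements on the series, on what has been measured and on what is new or still open speak of the compounds shown alone.

Results in a functional assay on the whole organism with Rattus norvegicus as the target (on this read-out higher numbers stand for an effect only at larger amounts of compound and lower numbers for an effect already at smaller amounts), so far
- compound 1 `CSc1nc(C)nc(SC)c1NC(=O)N(Cc1ccc(Oc2ccc(F)cc2)cc1)C1CCCCCC1` gives 0.069 mg/kg
- compound 2 `COc1cc(C)nc(OC)c1NC(=O)N(Cc1ccc(Oc2ccc(F)cc2)cc1)C1CCCCCC1` gives 0.032 mg/kg
- compound 3 `Cc1cc(C)c(NC(=O)N(Cc2ccc(Oc3ccc(F)cc3)cc2)C2CCCCCC2)c(C)n1` gives 0.044 mg/kg

Compound 3 at 0.044 mg/kg has no clear place in the order of these three, since a 1.6-fold lower number from compound 1 to compound 3 (0.20 log units; within the scatter) and a 1.4-fold higher number from compound 2 to compound 3 (0.14 log units; within the scatter) both stay within the scatter. Only a 2.2-fold lower number from compound 1 to compound 2 (0.33 log units; beyond the scatter) goes beyond it, and that step is modest.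

In compound 4 `Cc1ccc(NC(=O)N(Cc2ccc(Oc3ccc(F)cc3)cc2)C2CCCCCC2)c(Cl)n1` the group on the amide-type nitrogen changes again 2-chloro-6-methylpyridin-3-yl in place of 2,4,6-trimethylpyridin-3-yl on an amide-type nitrogen and 2-chloro-6-methylpyridin-3-yl stands in place of 2,4,6-trimethylpyridin-3-yl. The three measured steps all exchange the group at this same place, so they are the best guide available. Even the largest of them, a 2.2-fold lower number from compound 1 to compound 2 (0.33 log units; beyond the scatter), is modest. Among the measured compounds shown here, none of the measured compounds carries a chloro group, however, so the data cannot show how this particular exchange will behave, and the uncertainty is wider than for the earlier swaps.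

In this assay, for the measured compounds named here, the expected change, a 1.8-fold higher number from compound 3 to compound 4 (0.26 log units; within the scatter), is small and leans toward a higher number, with no step clearly beyond the scatter expected. For compound 4 the estimated value is 0.08 mg/kg (expected range 0.03 mg/kg to 0.3 mg/kg).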

Compound 4, dose for half-maximal effect: > 0.1 mg/kg
Compound 4: a limit, no number; the forecaster's own chance of this, stated with the estimate: 2%; middle value at least 1.2-fold (0.09 log units) from the limit.
By their numbers in this assay, from the lowest: compounds 2, 3 and 1 (each within the scatter of the next, the first and the last beyond it). At a limit, above all of these: compound 4.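

In this assay compound 4 gives no number, only a limit of the assay: the limit of > 0.1 mg/kg in this assay, at which 1 of the 4 values shown sits.
Even so, that limit shows that this place on the amide-type nitrogen is less forgiving than the first three compounds suggested, as 2-chloro-6-methylpyridin-3-yl in place of 2,4,6-trimethylpyridin-3-yl gives a step beyond the scatter (an at least 2.2-fold higher number from compound 3 to compound 4 (0.35 log units; beyond the scatter)), and the exchange against the group of compound 2 does too (an at least 3.1-fold higher number from compound 2 to compound 4 (0.49 log units; beyond the scatter)). Against the group of compound 1 the floor of the step stays within the scatter (an at least 1.4-fold higher number from compound 1 to compound 4 (0.16 log units; that floor lies within the scatter)), so this limit does not yet set compound 4 apart from compound 1.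

As far as these compounds go, how large the number for compound 4 really is stays open, and each of these steps could be larger than its floor. The compounds shown also cannot separate the arrival of the chlorine from the loss of methyl groups, a question that a 2-bromo-6-methylpyridin-3-yl or 2-amino-6-methylpyridin-3-yl group at this place would bear on.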